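From phenyl to 3-methoxyphenyl on compound 1

The source may hold more compounds than are shown below. What is called first, only, known or untested is meant among the compounds shown, and "the series" means these compounds.

In a functional assay on HT-29 cells (Homo sapiens) for antiproliferative activity, read by MTT assay, with a stated time of 48 h (a higher number here means a weaker inhibitor of growth, a lower number a stronger inhibitor of growth), compound 1 (`COC(=O)N1N=C(c2ccccc2)CC1c1cc(OC)c(OC)c(OC)c1`) gives 6260 nM, and compound 2 (`CCOC(=O)N1N=C(c2ccccc2)CC1c1cc(OC)c(OC)c(OC)c1`) gives 8920 nM. These two cannot be told apart, since the measured step is a 1.4-fold higher number from compound 1 to compound 2 (0.15 log units; within the scatter). Compound 3 (`CCCOC(=O)N1N=C(c2ccccc2)CC1c1cc(OC)c(OC)c(OC)c1`) reads > 10000 nM, which is a limit of the assay and not a number. The other two steps are an at least 1.5-fold higher number from compound 1 to compound 3 (0.20 log units; that floor lies within the scatter) and an at least 1.1-fold higher number from compound 2 to compound 3 (0.04 log units; that floor lies within the scatter). All three steps alter the saturated chain bound to an oxygen next to a carbonyl group.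

Compound 4 (`COC(=O)N1N=C(c2cccc(OC)c2)CC1c1cc(OC)c(OC)c(OC)c1`) differs elsewhere: methoxy in place of hydrogen on an aromatic carbon. Within the data shown here, no measured step touches this aromatic ring, so the steps above offer only weak guidance, and none of them shows a change beyond the scatter. With nothing pointing either way, no change beyond the scatter is expected in this assay. The expected step is a 1.1-fold lower number from compound 1 to compound 4 (0.06 log units; within the scatter). Compound 4 is estimated at 5500 nM, within an expected range of 1800 nM to 13000 nM.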

Compound 4, concentration for 50% growth inhibition: 1300 nM
Beside the measured number, compound 4's estimate is 4.2-fold (0.63 log units) above it; the whole stated range lies above it.
By their numbers in this assay, from the lowest: compound 4; then compounds 1 and 2 (each within the scatter of the next). At a limit, above all of these: compound 3.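

Within this assay the swap of phenyl for 3-methoxyphenyl gives a 4.8-fold lower number from compound 1 to compound 4 (0.68 log units; beyond the scatter) and is the first step shown to clear the scatter. This aromatic ring therefore responds to a change in a way that the saturated chain, in the steps shown, did not, though the finding rests on one pair of compounds.

On these data alone, whether a hydroxyl, an amine or a longer ether chain at this place would go further or fall back stays open, as does methoxy on other carbons of the ring. Nothing shown here bears on the reason for this step.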